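Swapping difluoromethyl for methyl on a sulfur

This account rests on a few compounds, and the source may have more. Where it says the series, first, only, none or still open, it means among the compounds named here.

Compound 1, `FC(F)c1ccccc1`, gives 2.4.
Compound 2, `O=[N+]([O-])c1ccc(S(=O)(=O)C(F)F)cc1`, gives 1.7.
Compound 3, `FC(F)SCCc1ccccc1`, gives 3.16.

These three numbers come from a physicochemical assay for lipophilicity, read by spectrophotometry, using the shake flask method, measured as octanol-water partition; a lower number here means a more polar compound, a higher number a more lipophilic compound. Among them compound 3 stands highest. Its nearest neighbour is compound 1, which sits lower by a gap beyond the usual scatter of this assay, and compound 2 sits furthest away, lower still by a gap that is also beyond the scatter. For the measured compounds named here, none of the three measured compounds differs from another in only one place, so no measured step shows directly what a single change does to the number.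

Compound 4, `CSCCc1ccccc1`, is the next compound to be measured in this assay. It differs from compound 3 in one place:

methyl in place of difluoromethyl on a sulfur

Without a measured step of this kind to lean on, the expectation rests on the standing of compound 3 alone. The change from compound 3 to compound 4 is expected to give a modest step downward, a number 0.36 log units lower from compound 3 to compound 4 (beyond the scatter), of a size that may sit just beyond the scatter. Compound 4 is therefore estimated at 2.8 in this assay, within a range from 2.4 to 3.2.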

Compound 4, partition coefficient: 2.95
Compound 4: the middle estimate sits 0.15 log units below what was measured; measured number inside the range.
By their numbers in this assay, from the lowest: compound 2; then compound 1; then compounds 4 and 3 (each within the scatter of the next).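

In this assay, for the compounds shown here, the one single change that can be read so far gives a number 0.21 log units lower from compound 3 to compound 4 (within the scatter), so the two compounds cannot be told apart in this assay. Going by these compounds alone, on a sulfur whose other neighbours are a saturated chain carbon, then, putting methyl in place of difluoromethyl removes two fluorine atoms and leaves the partition number within what repeated measurements would scatter over, something the earlier compounds could not show since none of them differed from another in only one place. The data shown offer no measured finding that could account for this result.

This is a single pair, so it cannot say whether the same swap would stay as quiet on a sulfur carrying a different neighbour, such as a longer chain or a ring directly attached. It also leaves open where other groups on this sulfur, such as trifluoromethyl or ethyl, would fall relative to the methyl and difluoromethyl pair.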